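The source may report more compounds than this note shows. Statements on the series, on what has been measured and on what is new or still open speak of the compounds shown alone.

Measured compounds:
- compound 1, `CC(=O)Nc1ccc(S(=O)(=O)Oc2ccccc2I)cc1` — in a functional assay on HT-1080 cells (Homo sapiens) for antiproliferative activity, read by sulforhodamine B assay, with a stated time of 48 h (a lower number here means a stronger inhibitor, a higher number a weaker inhibitor), compound 1 gives 17000 nM
- compound 2, `CC(C)(C)C(=O)Nc1ccc(S(=O)(=O)Oc2ccccc2I)cc1` — compound 2 gives 2600 nM
- compound 3, `CCNC(=O)Nc1ccc(S(=O)(=O)Oc2ccccc2I)cc1` — compound 3 gives 140 nM

Compound 3 holds the lowest number of the three. Its nearest neighbour is compound 2, reached by a 19-fold lower number from compound 2 to compound 3 (1.27 log units; beyond the scatter), and its furthest is compound 1, reached by a 120-fold lower number from compound 1 to compound 3 (2.08 log units; beyond the scatter); the remaining step, a 6.5-fold lower number from compound 1 to compound 2 (0.82 log units; beyond the scatter), is modest. All three steps change the group on the carbonyl carbon, and they show that the shared core responds strongly to what sits there.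

Compound 4, `O=C(Nc1ccc(S(=O)(=O)Oc2ccccc2I)cc1)NC1CC1`, differs from compound 3 in another place: cyclopropyl in place of ethyl on an amide-type nitrogen. Going by the values given here, no measured step alters the group on this nitrogen, so none of them speaks directly to this change; the measured steps only show that the ethylamino arm as a whole carries most of the potency. Among the compounds with values here, with no precedent for the swap itself, a change within the scatter is the most reasonable expectation. Compound 4 is therefore expected to give about 150 nM, between 50 nM and 500 nM, which would mean an expected step of a 1.1-fold higher number from compound 3 to compound 4 (0.03 log units; within the scatter).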

Compound 4, half-maximal inhibitory concentration: 1300 nM
The estimate for compound 4 lay 8.7-fold (0.94 log units) below the measured number, and the stated range ends below it.
By their numbers in this assay, from the lowest: compound 3; then compounds 4 and 2 (each within the scatter of the next); then compound 1.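

In this assay the group on this nitrogen proves to matter in its own right: a 9.3-fold higher number from compound 3 to compound 4 (0.97 log units; beyond the scatter) comes from cyclopropyl in place of ethyl alone, so the potency of the ethylamino arm does not carry over to cyclopropylamino. With cyclopropylamino on the carbonyl carbon, a 13-fold lower number from compound 1 to compound 4 (1.12 log units; beyond the scatter) still sets it apart from methyl, while a 2.0-fold lower number from compound 2 to compound 4 (0.30 log units; within the scatter) leaves it level with tert-butyl. Nothing available explains why this small change has so large an effect.

Open, on these data alone, is whether the loss goes with the ring or with the added carbon, a question that a propyl or isopropyl group on this nitrogen could settle. Also open, as far as these compounds go, is whether a methyl group or a longer butyl chain here would match ethyl.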